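A few compounds are considered here, and "the series" means these few. Any claim that something is new, unique, unknown or untested is made for them only; others in the source may bear on it.

In an assay for inhibition of inositol hexakisphosphate kinase 2 (Homo sapiens), read by colorimetric assay, coupled enzyme assay and malachite green, with a stated time of 120 min, in the presence of a further agent that is not named here (a higher number here means a weaker inhibitor, a lower number a stronger inhibitor), compound 2 `O=C(O)c1ccc2noc(-c3ccc(Oc4ccccc4)cc3)c2c1` gives 280 nM. Going by the values given here, it is one of only two compounds measured; the other, compound 1 `O=C(O)c1ccc2noc(-c3ccc(-c4ccncc4)cc3)c2c1`, gives 150 nM in this assay, and the step of a 1.9-fold higher number from compound 1 to compound 2 (0.27 log units; within the scatter) is within the scatter. Compound 3 `O=C(O)c1ccc2noc(-c3ccc(Oc4ccccn4)cc3)c2c1` differs from compound 2 by pyridin-2-yl in place of phenyl on an oxygen on an aromatic ring. Among the compounds with values here, the single measured step bears on this only loosely, since it changed a different group at a different place and itself stayed within the scatter. A step of no more than the scatter is therefore expected from compound 2 to compound 3, a 1.1-fold lower number from compound 2 to compound 3 (0.03 log units; within the scatter). Compound 3 is estimated at 260 nM, between 100 nM and 700 nM.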

Compound 3, half-maximal inhibitory concentration: 1190 nM
For compound 3 the middle estimate is 4.6-fold (0.66 log units) below the measured one; measured number outside the range, above it.
By their numbers in this assay, from the lowest: compounds 1 and 2 (each within the scatter of the next); then compound 3.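

With pyridin-2-yl in place of phenyl on this oxygen, a 4.3-fold higher number from compound 2 to compound 3 (0.63 log units; beyond the scatter) follows in this assay, the first step shown that lies beyond the scatter. The site therefore responds to a swap of one ring carbon for nitrogen, and a 7.9-fold higher number from compound 1 to compound 3 (0.90 log units; beyond the scatter) shows that (pyridin-2-yl)oxy also falls behind pyridin-4-yl on the aromatic carbon. No evidence given here accounts for this loss. As far as these compounds go, it remains open whether pyridin-3-yl or pyrimidin-2-yl on the same oxygen would follow phenyl or pyridin-2-yl, and whether an amide could stand in place of the carboxylic acid.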